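Pyridin-3-yl Replaces 3-Methylphenyl on the Amide Nitrogen

The source may hold more compounds than are shown below. What is called first, only, known or untested is meant among the compounds shown, and "the series" means these compounds.

Measured so far in a functional assay on the whole organism for inhibition, with Rattus norvegicus as the target, read by paw edema, at a dose of 100 mg/kg by the oral route; a lower number here means less inhibition, a higher number more inhibition at the dose given (going by the name of the read-out):
compound 1, `O=C(NCc1ccccc1)c1c(O)c2cccnc2n(-c2ccccc2)c1=O`, gives 1.6%
compound 2, `CN(C)CCNC(=O)c1c(O)c2cccnc2n(-c2ccccc2)c1=O`, gives 22.6%
compound 3, `Cc1cccc(NC(=O)c2c(O)c3cccnc3n(-c3ccccc3)c2=O)c1`, gives 14.2%

Compound 3 holds the second highest of the three numbers. Its nearest neighbour is compound 2, a step that lies within the scatter (a number 8.4 percentage points lower from compound 2 to compound 3 (within the scatter)), while compound 1 lies further off, beyond the scatter (a number 12.6 percentage points higher from compound 1 to compound 3 (beyond the scatter)). The other step, a number 21 percentage points higher from compound 1 to compound 2 (beyond the scatter), also changes the group on the amide-type nitrogen.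

Compound 4, `O=C(Nc1cccnc1)c1c(O)c2cccnc2n(-c2ccccc2)c1=O`, differs from compound 3 in one place: pyridin-3-yl in place of 3-methylphenyl on an amide-type nitrogen. Among the measured compounds shown here, no measured step exchanges one six-membered aromatic ring for another at this nitrogen, so the measured steps bear on it only loosely; they show that a change at this nitrogen can move the number modestly or not at all. With a single ring atom exchanged and the rest of the shared core untouched, no step beyond the scatter is expected, and compound 4 is estimated to give 16% (range 4% to 30%), a step of a number 1.8 percentage points higher from compound 3 to compound 4 (within the scatter) that is expected to stay within the scatter.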

Compound 4, a percentage reported as inhibition, in the whole organism at one dose (the size of the read-out at that dose, not a potency): 30.3%
For compound 4 the middle estimate is 14.3 percentage points below the measured one; the measured number lies above the stated range.
By their numbers in this assay, from the lowest: compound 1; then compounds 3, 2 and 4 (each within the scatter of the next, the first and the last beyond it).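

Placing pyridin-3-yl on the amide-type nitrogen shows that exchanging one six-membered aromatic ring for another at this position can produce a step beyond the scatter in this assay (a number 16.1 percentage points higher from compound 3 to compound 4 (beyond the scatter)). The step from the benzyl compound also lies beyond the scatter (a number 28.7 percentage points higher from compound 1 to compound 4 (beyond the scatter)), whereas pyridin-3-yl and 2-(dimethylamino)ethyl are not separated (a number 7.7 percentage points higher from compound 2 to compound 4 (within the scatter)). An aromatic ring with 1 hetero atom therefore belongs with the 2-(dimethylamino)ethyl chain here, at a level the benzyl group does not reach.

This change both removes the methyl group and brings in the ring nitrogen, so the compounds shown cannot separate the two; an unsubstituted phenyl group would bear on this, while pyridin-2-yl and pyridin-4-yl would test the place of the ring nitrogen. Nothing available here gives a measured explanation for the step.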